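Bromo on the Phenyl Ring: Expecting Little Change

This account rests on a few compounds, and the source may have more. Where it says the series, first, only, none or still open, it means among the compounds named here.

Measured in a functional assay on HepG2 cells (Homo sapiens) for inhibition, read by MTT assay, with a stated time of 72 h; on this read-out lower numbers stand for stronger inhibition and higher numbers for weaker inhibition:
- Compound 1, `O=C(Nc1cccc(OCc2cn(-c3ccccc3)nn2)c1)Nc1ccc(Cl)c(C(F)(F)F)c1`: 1780 nM
- Compound 2, `CCc1ccc(-n2cc(COc3cccc(NC(=O)Nc4ccc(Cl)c(C(F)(F)F)c4)c3)nn2)cc1`: 1950 nM
- Compound 3, `O=C(Nc1cccc(OCc2cn(-c3cccc(Cl)c3)nn2)c1)Nc1ccc(Cl)c(C(F)(F)F)c1`: 2020 nM

All three compounds share one core and differ only in what sits on the phenyl ring attached to the triazole nitrogen. Compound 1 carries the bare phenyl, and its number sits within the scatter of both neighbours: a 1.1-fold higher number from compound 1 to compound 2 (0.04 log units; within the scatter) and a 1.1-fold higher number from compound 1 to compound 3 (0.05 log units; within the scatter). Compounds 2 and 3 are likewise indistinguishable from each other, a 1.0-fold higher number from compound 2 to compound 3 (0.02 log units; within the scatter).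

Compound 4, `O=C(Nc1cccc(OCc2cn(-c3ccc(Br)cc3)nn2)c1)Nc1ccc(Cl)c(C(F)(F)F)c1`, is the next member of this series. Compared with compound 1 the change is bromo in place of hydrogen on an aromatic carbon.

For the measured compounds named here, two measured steps bear directly on this change, since each also puts a single group in place of hydrogen on that phenyl ring: ethyl in compound 2 and chloro in compound 3. Neither moved the number beyond the scatter. A bromo group is a close relative of chloro in this sense, so no step beyond the scatter is expected for compound 4 either: a 1.1-fold higher number from compound 1 to compound 4 (0.03 log units; within the scatter).

Compound 4 is therefore estimated at 1900 nM in this assay, with a likely range from 950 nM to 3800 nM.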

Compound 4, half-maximal inhibitory concentration: 2730 nM
For compound 4 the middle estimate is 1.4-fold (0.16 log units) below the measured one, within the range that was stated.
By their numbers in this assay, from the lowest: compounds 1, 2, 3 and 4 (each within the scatter of the next).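

In this assay, bromo in place of hydrogen on the phenyl ring gives a 1.5-fold higher number from compound 1 to compound 4 (0.19 log units; within the scatter) and so stays close to the bare phenyl, even though this group sits para to a large group. The same holds against the two substituted rings, with a 1.4-fold higher number from compound 2 to compound 4 (0.15 log units; within the scatter) when 4-bromophenyl replaces 4-ethylphenyl and a 1.4-fold higher number from compound 3 to compound 4 (0.13 log units; within the scatter) when it replaces 3-chlorophenyl. Bromo thus joins ethyl and chloro as a third group on this ring, and among these four compounds no change to the ring separates one number from another by more than the usual scatter of this cell assay.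

From the compounds shown here alone, it remains open whether a quite different group on this phenyl ring, such as an amine or a carboxylic acid, would produce a step beyond the scatter. The data shown also offer no measurement that explains why these ring changes leave the number so little moved.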